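Selenium-linked bisacyl series: benzyl versus methyl on selenium

A few compounds are considered here, and "the series" means these few. Any claim that something is new, unique, unknown or untested is made for them only; others in the source may bear on it.

Measured compounds:
- compound 1, `C[Se]/C(=N\C(=O)c1cccs1)NC(=O)c1cccs1`: 6070 nM
- compound 2, `O=C(/N=C(/NC(=O)c1ccno1)[Se]Cc1ccccc1)c1ccno1`: 20000 nM
- compound 3, `O=C(/N=C(/NC(=O)c1cccs1)[Se]Cc1ccccc1)c1cccs1`: 29500 nM

All three were tested in a functional assay on K562 cells (Homo sapiens) for cytotoxicity, read by MTT assay, with a stated time of 72 h; a higher number here means a weaker inhibitor of growth, a lower number a stronger inhibitor of growth. Compound 1 gives 6070 nM and compound 3 gives 29500 nM. These two share one core, and the step between them is a 4.9-fold lower number from compound 3 to compound 1 (0.69 log units; beyond the scatter); the change is hydrogen in place of phenyl on a saturated chain carbon bound to a selenium atom. Compound 2 gives 20000 nM; its core differs from that of compound 3, and the difference between the two cores is not broken down here. The values of compound 2 and compound 3 lie within the scatter of each other, so nothing is said about their order.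

Compound 4, `C[Se]/C(=N\C(=O)c1ccno1)NC(=O)c1ccno1`, has not yet been measured in this assay. It stands to compound 2 as compound 1 stands to compound 3: the change is hydrogen in place of phenyl on a saturated chain carbon bound to a selenium atom, at the same place as before. Among the compounds here this change occurs twice in all, once measured and once not.

For the measured compounds named here, the expectation for compound 4 rests on the one measured instance, because a 4.9-fold lower number from compound 3 to compound 1 (0.69 log units; beyond the scatter) was the step seen on the other core. The same kind of change on the core of compound 2 is expected to give a step of about a 4.4-fold lower number from compound 2 to compound 4 (0.65 log units; beyond the scatter); with only one prior case, the spread is kept wide. Compound 4 is therefore estimated at 4500 nM, with a range from 1500 nM to 14000 nM.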

Compound 4, concentration for 50% growth inhibition: 870 nM
Estimate against measurement, compound 4: 5.2-fold (0.71 log units) above, outside the stated range (below it).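

The change from benzyl to methyl lowers the number in this assay on both cores, and on the core of compound 2 the new step is a 23-fold lower number from compound 2 to compound 4 (1.36 log units; beyond the scatter). The direction of the change carries from one core to the other, but its size does not, so a step measured on one of these cores is a poor guide to the size of the step on the other: the same change on two cores in this assay, a 4.9-fold lower number (0.69 log units; beyond the scatter) from compound 3 to compound 1 and a 23-fold lower number (1.36 log units; beyond the scatter) from compound 2 to compound 4, 4.7-fold (0.67 log units) apart, beyond the scatter of two such steps. These two pairs do not show which feature of the cores sets the size of the step, and two cores with one pair each give no rule for the change beyond these four compounds.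

As far as these compounds go, only benzyl and methyl appear at this place, so it remains open how an ethyl group, a longer chain or a chain ending in a carboxylic acid or an amine would compare with them on either core. From the compounds shown here alone, it also remains open whether the change keeps its direction on a third core, and whether the gap between the two steps would persist with further pairs in this assay.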